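The source may hold more compounds than are shown below. What is called first, only, known or untested is meant among the compounds shown, and "the series" means these compounds.

Compound 1 `COC(=O)c1cccc(-c2cnc(C(=O)CCCCCCc3ccccc3)o2)c1` gives 12 nM in an assay (Rattus norvegicus) for inhibition of Fatty-acid amide hydrolase 1 (Homo sapiens); on this read-out higher numbers stand for weaker inhibition and lower numbers for stronger inhibition.
Compound 2 `O=C(CCCCCCc1ccccc1)c1ncc(-c2ccc([N+](=O)[O-])cc2)o1` gives 50 nM.
Compound 3 `O=C(CCCCCCc1ccccc1)c1ncc(-c2cc(C(F)(F)F)ccn2)o1` gives 3.5 nM.

Among these three numbers compound 2 has the highest, and so the weakest inhibition shown; compound 1 lies below it by a gap beyond the usual scatter, and compound 3 lies further below still. Compound 4 `O=C(CCCCCCc1ccccc1)c1ncc(-c2ccncn2)o1` has not yet been measured. It differs from compound 2 in one place: pyrimidin-4-yl in place of 4-nitrophenyl on an aromatic carbon. Going by the values given here, no single-change step between measured compounds is known, so the size of this step can only be guessed. Stronger inhibition is expected because compound 3 gives 3.5 nM while also carrying a six-membered ring with hetero atoms. The expected step is a 5.0-fold lower number from compound 2 to compound 4 (0.70 log units; beyond the scatter). Compound 4 is estimated at 10 nM, within 3 nM to 40 nM.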

Compound 4, inhibition constant: 2.3 nM
Compound 4: the middle estimate sits 4.3-fold (0.64 log units) above what was measured; measured number outside the range, below it.
By their numbers in this assay, from the lowest: compounds 4 and 3 (each within the scatter of the next); then compound 1; then compound 2.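

Swapping 4-nitrophenyl for pyrimidin-4-yl on this aromatic carbon, next to the ring oxygen, gives a 22-fold lower number from compound 2 to compound 4 (1.34 log units; beyond the scatter) in this assay, a large step beyond the scatter. Going by these compounds alone, it is the first single change read at this position, and it shows that the group held here can strongly shift inhibition. No measurement shown explains this gain.

As far as these compounds go, it remains open whether the gain follows the ring nitrogens or the loss of the nitro group. An unsubstituted phenyl ring at this position would separate the two.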